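The source may hold more compounds than are shown below. What is called first, only, known or untested is meant among the compounds shown, and "the series" means these compounds.

Measured compounds and their values:

- compound 1, `C[C@@H]1CN(c2sc(C(F)(F)F)nc2-c2nc3cc(OCCO)ccc3[nH]2)CCN1C(=O)Cn1cnc2cccnc21`: 549 ug/mL
- compound 2, `Cc1nc(C)n(CC(=O)N2CCN(c3sc(C(F)(F)F)nc3-c3nc4ccc(C5CCN(C)CC5)cc4[nH]3)C[C@H]2C)n1`: a limit, > 1020 ug/mL
- compound 3, `Cc1nn(CC(=O)N2CCN(c3sc(C(F)(F)F)nc3-c3nc4ccccc4[nH]3)C[C@H]2C)cc1CN(C)C`: 645 ug/mL

The read-out throughout is a physicochemical assay for solubility, in simulated intestinal fluid; on this read-out higher numbers stand for higher solubility and lower numbers for lower solubility. Compound 1 gives 549 ug/mL in this assay. For compound 2 this assay reports only a limit, > 1020 ug/mL, and not a number. Compound 3 gives 645 ug/mL, the higher of the two numbers available, although its nearest neighbour, compound 1, sits within the usual scatter of it, so the two cannot be told apart.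

The step of interest leads from compound 3 to compound 4, `Cc1nc(C)n(CC(=O)N2CCN(c3sc(C(F)(F)F)nc3-c3nc4ccccc4[nH]3)C[C@H]2C)n1`, which has not yet been measured in this assay. The change is 3,5-dimethyl-1H-1,2,4-triazol-1-yl in place of 4-((dimethylamino)methyl)-3-methyl-1H-pyrazol-1-yl on a saturated chain carbon bound to a carbonyl carbon. Within the data shown here, no measured pair shows this change directly, so there is no measured step to lean on. The expectation is a small move, with compound 4 estimated at 400 ug/mL and a range from 150 ug/mL to 1000 ug/mL. This corresponds to an expected step of a 1.6-fold lower number from compound 3 to compound 4 (0.21 log units; within the scatter), which would not go clearly beyond the scatter.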

Compound 4, solubility: > 850 ug/mL
Compound 4: a limit, no number; the forecaster's own chance of this, stated with the estimate: 15%; at least 2.1-fold (0.32 log units) between middle value and limit.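

In this assay compound 4 gives > 850 ug/mL, which is a limit and not a number. Putting 3,5-dimethyl-1H-1,2,4-triazol-1-yl in place of 4-((dimethylamino)methyl)-3-methyl-1H-pyrazol-1-yl on a saturated chain carbon bound to a carbonyl carbon gives an at least 1.3-fold higher number from compound 3 to compound 4 (0.11 log units; that floor lies within the scatter), so a gain is not established, but the reading at this position does not depend on keeping the dimethylamino part. The step between compound 2 and compound 4 cannot be read, since both values are limits.

As far as these compounds go, how far compound 4 really lies past its limit stays open, and with it the true size of the step. Also open, from the compounds shown here alone, is whether a carboxylic acid or a morpholine on that same carbon would read as high in this assay.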